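The source may hold more compounds than are shown below. What is called first, only, known or untested is meant among the compounds shown, and "the series" means these compounds.

Compound 1, `COc1cc(C(=O)NS(=O)(=O)c2ccccc2)ccc1Cc1cn(C2CCCC2)c2ccc(NC(=O)OC3CCCC3)cc12`, measured in an assay on isolated protein (Cavia porcellus) with cysteinyl leukotriene receptor (Homo sapiens) as the target; a lower number here means a less potent compound, a higher number a more potent compound, by a factor of ten per unit of this negative logarithm: 7.84
Compound 2, `COc1cc(C(=O)O)ccc1Cn1ccc2ccc(NC(=O)OC3CCCC3)cc21`, measured in this assay: 7.8

Compound 1 holds the higher of these two numbers, but compound 2 sits within the usual scatter of it, so the two cannot be ranked. For the measured compounds named here, no step between measured compounds is available here.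

Compound 3, `CCCn1cc(Cc2ccc(C(=O)NS(=O)(=O)c3ccccc3)cc2OC)c2cc(NC(=O)OC3CCCC3)ccc21`, differs from compound 1 in one place: propyl in place of cyclopentyl on an aromatic nitrogen. Nothing measured covers a change of this kind, so only a small shift is expected, if any beyond the scatter. For compound 3 the expected value in this assay is 7.6, with a range from 7 to 8.2. This estimate corresponds to a step of a number 0.24 log units lower from compound 1 to compound 3 (within the scatter).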

Compound 3, negative logarithm of the antagonist equilibrium constant: 8.44
Estimate against measurement, compound 3: 0.84 log units below; measured number outside the range, above it.
By their numbers in this assay, from the lowest: compounds 2 and 1 (each within the scatter of the next); then compound 3.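

This position on the aromatic nitrogen is sensitive to the group it carries: in this assay, replacing cyclopentyl with propyl gives a number 0.60 log units higher from compound 1 to compound 3 (beyond the scatter). So a ring is not required here, and the group with fewer heavy atoms gives the higher number in this pair. No measurement available here explains the gain.

This single pair cannot show whether the number depends on chain length or on the loss of the ring. An ethyl group, a butyl chain or a cyclopropyl ring at this position would leave that question open.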